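The source may hold more compounds than are shown below. What is called first, only, known or untested is meant among the compounds shown, and "the series" means these compounds.

Working notes on the series. Compound 1 `O=C(Nc1ccc(Sc2nc3ccccc3s2)c(Cl)c1)c1cccc(Br)c1` is the parent here. In an assay for inhibition of HSP60/HSP10 (Homo sapiens), with a stated time of 60 min (on this read-out higher numbers stand for weaker inhibition and lower numbers for stronger inhibition), compound 1 gives > 100000 nM, which is a limit of the assay and not a number. Compound 2 `O=C(Nc1ccc(Sc2nc3ccccc3s2)cc1)c1cccc(Br)c1` sits at the same boundary: in this assay compound 2 gives > 100000 nM, again a limit. Among the measured compounds shown here, the only measured step, a step that the two limits leave unreadable from compound 1 to compound 2, is therefore unreadable. For the measured compounds named here, compound 3 `O=C(Nc1ccccc1)c1cc(Br)cc(Br)c1O` is the one compound with a number, giving 63000 nM in this assay. Compound 4 `COc1ccccc1C(=O)Nc1ccc(Sc2nc3ccccc3s2)c(Cl)c1` differs from compound 1 by 2-methoxyphenyl in place of 3-bromophenyl on a carbonyl carbon. Going by the values given here, no measured step covers this change. Given (the limit of > 100000 nM in this assay, at which 2 of the 3 values shown sit), compound 4 is expected to stay near that boundary, with the step from compound 1 estimated as a number no higher from compound 1 to compound 4 (the limit leaves the size open). Compound 4 is expected at 100000 nM, within 30000 nM to 300000 nM.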

Compound 4, half-maximal inhibitory concentration: > 100000 nM
Compound 4 ended at the assay's limit (the forecaster's own chance of this, stated with the estimate: 65%); the middle value lies on the limit itself.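

Among the compounds shown here, compound 1 and compound 4 both give limits in this assay, and no step between them can be read. The compounds shown leave open whether 2-methoxyphenyl in place of 3-bromophenyl changes this read-out at all.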